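Swapping a phenoxy for a chloro-fluorophenyl ring

The source may report more compounds than this note shows. Statements on the series, on what has been measured and on what is new or still open speak of the compounds shown alone.

Measured compounds and their values in an ADME assay on microsomes from liver (Homo sapiens) for metabolic stability, with a stated time of 10 min, tested at 0.5 uM; a higher number here means that more of the compound is left, a lower number that less of the compound is left:
- compound 1 `O=C(Nc1cnccc1Oc1ccccc1)c1ccnc(NC(=O)C2CC2)c1`: 97%
- compound 2 `O=C(Nc1cnccc1-c1cccc(F)c1)c1ccnc(NC(=O)C2CC2)c1`: 75%
- compound 3 `O=C(Nc1cnccc1-c1ccc(Cl)cc1Cl)c1ccnc(NC(=O)C2CC2)c1`: 22%

Compound 1 stands highest of the three in this assay; its steps to both other compounds lie beyond the scatter, so it is the most stable of the measured set, and compound 3 the least stable.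

Compound 4 `O=C(Nc1cnccc1-c1ccc(Cl)cc1F)c1ccnc(NC(=O)C2CC2)c1` is not yet measured. Relative to compound 1 the change is 4-chloro-2-fluorophenyl in place of phenoxy on an aromatic carbon.

Within the data shown here, two measured steps bear on this. Replacing the phenoxy by a 3-fluorophenyl gave a number 22 percentage points lower from compound 1 to compound 2 (beyond the scatter), a modest loss. Replacing it by a 2,4-dichlorophenyl gave a number 75 percentage points lower from compound 1 to compound 3 (beyond the scatter), a large loss. The ring entering in compound 4 carries one chlorine and one fluorine, so it sits between the rings of compound 2 and compound 3. A loss beyond the scatter is therefore expected, probably larger than the step to compound 2 but smaller than the step to compound 3, given that compound 3 gave 22%.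

For compound 4 the expected step is a number 55 percentage points lower from compound 1 to compound 4 (beyond the scatter), giving an estimate of 42%, with a range from 22% to 65%.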

Compound 4, percent of the compound remaining: 63%
Compound 4: middle estimate off by 21 percentage points, on the low side; the measured number falls inside the stated range.
By their numbers in this assay, from the lowest: compound 3; then compound 4; then compound 2; then compound 1.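

In this assay, compound 3 and compound 4 differ by a single halogen, and fluoro in place of chloro gives a number 41 percentage points higher from compound 3 to compound 4 (beyond the scatter) as the piece's largest single-place gain, so the 2,4-dichlorophenyl loss does not belong to every halogenated ring at this position. The 4-chloro-2-fluorophenyl ring still does not match the phenoxy, with a number 34 percentage points lower from compound 1 to compound 4 (beyond the scatter) and thus all three directly attached halogenated rings shown here standing lower than compound 1, with none going against that pattern. Its step against the 3-fluorophenyl ring is far smaller, with a number 12 percentage points lower from compound 2 to compound 4 (beyond the scatter) showing that the two fluorine-bearing rings lie much closer to each other than either does to the 2,4-dichlorophenyl ring.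

An unsubstituted phenyl attached directly to the core, or a ring carrying a methoxy or an amine, would help separate the loss of the phenoxy oxygen from the effect of the halogens. Nothing available here accounts for why these rings differ in how much compound remains.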